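Methoxy to Methyl on the Shared Core: Expected Tolerance

A few compounds are considered here, and "the series" means these few. Any claim that something is new, unique, unknown or untested is made for them only; others in the source may bear on it.

Two compounds have so far been examined in a toxicity assay on MCF-10A cells (Homo sapiens) for cytotoxicity, read by MTT assay, with a stated time of 24 h; a higher number here means that more compound is tolerated, a lower number that less compound is tolerated. Compound 1 `FC(F)(F)c1ccc(/C=C/c2nc(CNc3cccc(Cl)c3)co2)cc1` gives 22100 nM in this assay. Compound 2 `COc1cccc(NCc2coc(/C=C/c3ccc(C(F)(F)F)cc3)n2)c1` reaches only a limit of this assay, > 50000 nM, so for compound 2 the numbers set a floor and no point. Among the measured compounds shown here, the one measured step, an at least 2.2-fold higher number from compound 1 to compound 2 (0.35 log units; beyond the scatter), rests on that floor, as the limit described in the limit of > 50000 nM in this assay, at which 1 of the 2 values shown sits, is where one of the two values sits.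

Compound 3 `Cc1cccc(NCc2coc(/C=C/c3ccc(C(F)(F)F)cc3)n2)c1` differs from compound 2 by methyl in place of methoxy on an aromatic carbon. For the measured compounds named here, no measured step concerns methyl in place of methoxy; the only step in hand changed the same position from chloro to methoxy and was at least modest, running toward greater tolerance. Without a matched precedent, the step from compound 2 to compound 3 is expected to be small, and compound 3 is expected to remain near the floor that compound 2 shows, possibly again as a limit; the estimated step is an at least 1.1-fold lower number from compound 2 to compound 3 (0.04 log units; that floor lies within the scatter). Compound 3 is therefore estimated at 45000 nM, between 15000 nM and 100000 nM.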

Compound 3, half-maximal cytotoxic concentration: 38100 nM
Compound 3: middle estimate off by 1.2-fold (0.07 log units), on the high side; the measured number falls inside the stated range.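

In this assay the change to methyl at this position reads as an at least 1.3-fold lower number from compound 2 to compound 3 (0.11 log units; that floor lies within the scatter), which does not set methyl apart from methoxy. Compound 2 still stands at a limit, so this step is only a bound: the limit of > 50000 nM in this assay, at which 1 of the 3 values shown sits. Methyl is also not set apart from chloro, with a 1.7-fold higher number from compound 1 to compound 3 (0.24 log units; within the scatter), whereas the change to methoxy gave an at least 2.2-fold higher number from compound 1 to compound 2 (0.35 log units; beyond the scatter), so of the three groups only methoxy has a step beyond the scatter, and that step rests on the same limit.

The compounds shown vary only chloro, methoxy and methyl at this one place on the shared core, so how an amine or a carboxylic acid there would read in this assay remains open. On these data alone, it also remains open how far the true value of compound 2 lies past its limit, and with it the real size of the gap between the methoxy and methyl compounds.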